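A Thiazole Ester Replaces the Isoxazole on the Shared Core

This account rests on a few compounds, and the source may have more. Where it says the series, first, only, none or still open, it means among the compounds named here.

Of the compounds shown here, three sharing one core have been measured in a functional assay on HeLa cells (Homo sapiens) for antiproliferative activity, read by MTT assay, with a stated time of 48 h; on this read-out higher numbers stand for weaker inhibition and lower numbers for stronger inhibition. Compound 1 `CC1(C)CC(NC(=O)c2ccc(Nc3ncc([N+](=O)[O-])c(N4CCN(c5ccc(F)cc5)CC4)n3)cc2)CC(C)(C)N1[O]` gives 25300 nM, compound 2 `Cc1cc(Nc2nc(Nc3ccc(C(=O)NC4CC(C)(C)N([O])C(C)(C)C4)cc3)ncc2[N+](=O)[O-])no1` gives 7360 nM, and compound 3 `Cc1cc(Nc2nc(Nc3ccc(C(=O)NC4CC(C)(C)N([O])C(C)(C)C4)cc3)ncc2[N+](=O)[O-])n[nH]1` gives 29100 nM. Compound 2 thus holds the lowest number of the three, with compound 1 and compound 3 both beyond the scatter above it. Within the data shown here, the only single-point step in the set, a 4.0-fold higher number from compound 2 to compound 3 (0.60 log units; beyond the scatter), concerns the same position that is altered in compound 4 `CCOC(=O)c1csc(Nc2nc(Nc3ccc(C(=O)NC4CC(C)(C)N([O])C(C)(C)C4)cc3)ncc2[N+](=O)[O-])n1`, where the change is 4-(ethoxycarbonyl)-1,3-thiazol-2-yl in place of 5-methyl-1,2-oxazol-3-yl on a nitrogen on an aromatic ring. That lone step was modest and weakening, and nothing directly tests an ethoxycarbonyl thiazole, so a weakening step of comparable or smaller size is expected, giving a 1.6-fold higher number from compound 2 to compound 4 (0.21 log units; within the scatter). Compound 4 is therefore estimated at 12000 nM, within 4000 nM to 40000 nM.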

Compound 4, half-maximal inhibitory concentration: 3790 nM
The estimate for compound 4 lay 3.2-fold (0.50 log units) above the measured number; the whole stated range lies above it.
By their numbers in this assay, from the lowest: compounds 4 and 2 (each within the scatter of the next); then compounds 1 and 3 (each within the scatter of the next).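

In this assay there is a 1.9-fold lower number from compound 2 to compound 4 (0.29 log units; within the scatter) and so the position on a nitrogen on an aromatic ring holds the 4-(ethoxycarbonyl)-1,3-thiazol-2-yl group, with more heavy atoms than 5-methyl-1,2-oxazol-3-yl, without a change beyond the scatter. Against the 5-methyl-1H-pyrazol-3-yl group there is a 7.7-fold lower number from compound 3 to compound 4 (0.89 log units; beyond the scatter) and so compound 3 now stands apart from both other groups at this position. Nothing available here explains these differences.

Whether the thiazole ring or the ethoxycarbonyl group accounts for the number of compound 4 remains open. An unsubstituted thiazol-2-yl group or a carboxylic acid in place of the ethyl ester would separate the two.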